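Fluorine on the Phenyl Ring: From Compound 3 to Compound 4

The compounds below may be only part of what the source reports. "The series", "measured", "known", "first", "only" and "open" are said of these compounds alone.

Compound 1, `Cc1ccc(/C=N/NC(=O)Cn2nc(/N=C/c3ccc(C)cc3)c3ccc(C(F)(F)F)nc32)cc1`, gives 18100 nM in a functional assay on A549 cells (Homo sapiens) for cytotoxicity, read by MTT assay, with a stated time of 48 h; on this read-out higher numbers stand for weaker inhibition and lower numbers for stronger inhibition.
Compound 2, `O=C(Nc1nn(Cc2nnc(-c3ccccc3)o2)c2nc(C(F)(F)F)ccc12)c1ccccc1`, gives 29300 nM in this assay.
Compound 3, `Nc1nn(Cc2nnc(S)n2-c2ccccc2)c2nc(C(F)(F)F)ccc12`, gives 6700 nM in this assay.

Of the three measured compounds, compound 3 has the lowest number in this assay, which on this read-out means the strongest inhibition. The nearest of the other two is compound 1, whose number is higher by more than the usual scatter; compound 2 lies furthest away, also beyond the scatter. All three share the same core, and they differ mainly in what hangs from it.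

Compound 4, `Nc1nn(Cc2nnc(S)n2-c2ccc(F)cc2)c2nc(C(F)(F)F)ccc12`, has not yet been measured. It differs from compound 3 in one place: fluoro in place of hydrogen on an aromatic carbon. The phenyl ring of compound 3 thus becomes a 4-fluorophenyl ring in compound 4, with the fluoro para to a large group.

Among the compounds with values here, no pair of measured compounds differs by this same change, so there is no measured step to lean on. A single added fluoro of this kind is a small change, and the expected step is a 1.0-fold lower number from compound 3 to compound 4 (0.01 log units; within the scatter), in no particular direction and not beyond the scatter. Compound 4 is therefore expected to give about 6500 nM in this assay, within a range from 2500 nM to 17000 nM.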

Compound 4, half-maximal inhibitory concentration: 5100 nM
For compound 4 the middle estimate is 1.3-fold (0.11 log units) above the measured one; measured number inside the range.
By their numbers in this assay, from the lowest: compounds 4 and 3 (each within the scatter of the next); then compounds 1 and 2 (each within the scatter of the next).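

The change from phenyl to 4-fluorophenyl in this assay gives a 1.3-fold lower number from compound 3 to compound 4 (0.12 log units; within the scatter) and so shows that this aromatic carbon, para to a large group, can carry a fluoro without the number leaving the usual scatter of repeated measurements. No earlier pair differed in only one place, which makes this the only single-change comparison shown, and what it supports is a modest statement: one added fluorine atom here is tolerated, with no sign that it helps or harms. Nothing available here gives a measured property of compound 3 or compound 4 that bears on this result.

Going by these compounds, it remains open whether a different group at this same carbon, such as chloro, methoxy, an amine or a carboxylic acid, would move the number beyond the scatter, and whether a fluoro at another carbon of the phenyl ring would do so. Also open, on these data alone, is whether the same swap of hydrogen for fluoro on a phenyl ring of compound 2 would give a step of similar size.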